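Swapping Cyclopropyl for Pyridin-2-ylmethyl on the Core Nitrogen

This account rests on a few compounds, and the source may have more. Where it says the series, first, only, none or still open, it means among the compounds named here.

Compound 1 `COc1ccc(C#N)cc1CSc1nc2cc(NC(=O)C3CC3)ccc2n1C(C)C` gives only a limit in an assay on isolated protein for inhibition of Gonadotropin-releasing hormone receptor (Rattus norvegicus) (a lower number here means a stronger inhibitor, a higher number a weaker inhibitor), namely > 10000 nM, so no number is known for it. Compound 2 `COc1ccc([N+](=O)[O-])cc1CSc1nc2cc(NC(=O)NC(C)(C)C)ccc2n1C1CC1` gives 860 nM in this assay, the only number shown. The other value, that of compound 1, is a limit (the limit of > 10000 nM in this assay, at which 1 of the 2 values shown sits). Compound 3 `COc1ccc([N+](=O)[O-])cc1CSc1nc2cc(NC(=O)NC(C)(C)C)ccc2n1Cc1ccccn1` differs from compound 2 by (pyridin-2-yl)methyl in place of cyclopropyl on an aromatic nitrogen, so (pyridin-2-yl)methyl stands in place of cyclopropyl on an aromatic nitrogen. Within the data shown here, no measured step of this kind exists here. The step of a 1.7-fold higher number from compound 2 to compound 3 (0.24 log units; within the scatter) is expected to be small, if anything toward weaker binding. Compound 3 is estimated at 1500 nM, within 400 nM to 6000 nM.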

Compound 3, half-maximal inhibitory concentration: 670 nM
For compound 3 the middle estimate is 2.2-fold (0.35 log units) above the measured one, within the range that was stated.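

On the aromatic nitrogen of the shared core, (pyridin-2-yl)methyl can stand in place of cyclopropyl with binding that cannot be told apart in this assay: the step is a 1.3-fold lower number from compound 2 to compound 3 (0.11 log units; within the scatter). This position therefore accepts a group with more heavy atoms and a six-membered aromatic ring, not only a small three-membered ring. Nothing measured here gives a reason for this result.

Going by these compounds, whether the ring nitrogen of the pyridine matters remains open, and a plain benzyl group would test that. On these data alone, how an aminoethyl chain or a carboxylic acid would fare on this nitrogen also remains open.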